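The source may hold more compounds than are shown below. What is called first, only, known or untested is meant among the compounds shown, and "the series" means these compounds.

Measured compounds:
compound 1, `COCc1cc(CN2CCCC2)c(O)c2ncccc12`, 3550 nM
compound 2, `CCOCc1cc(CN2CCCC2)c(O)c2ncccc12`, 5250 nM
compound 3, `CCOCc1cc(CN2CCCCC2)c(O)c2ncccc12`, 7080 nM

In a functional assay on MES-SA/Dx5 cells (Homo sapiens) for inhibition, with a stated time of 72 h, in the presence of a further agent that is not named here (a lower number here means a stronger inhibitor, a higher number a weaker inhibitor), compound 1 gives 3550 nM. Compound 2 differs from compound 1 by methyl in place of hydrogen on a saturated chain carbon bound to an oxygen on a saturated carbon, and the step is a 1.5-fold higher number from compound 1 to compound 2 (0.17 log units; within the scatter). Compound 3 differs from compound 2 in the amine part, and the step is a 1.3-fold higher number from compound 2 to compound 3 (0.13 log units; within the scatter). Both steps stay within the usual scatter, so the three measured values cannot be ranked against one another; compound 3 stands with the highest number of the three, yet even its gap to compound 1 lies within the scatter.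

Compound 4, `CCCOCc1cc(CN2CCCCC2)c(O)c2ncccc12`, has not yet been measured in this assay. It differs from compound 3 by methyl in place of hydrogen on a saturated chain carbon, two bonds along the chain from an oxygen on a saturated carbon. Among the compounds with values here, this is the same kind of change as the one from compound 1 to compound 2, but not the same: there the added methyl sits on a saturated chain carbon bound to an oxygen on a saturated carbon, whereas here it sits on a saturated chain carbon two bonds along the chain from an oxygen on a saturated carbon. The difference between the core of compound 1 and the core of compound 3 is not broken down here.

For compound 4 the step from compound 3 is expected to be a 1.3-fold higher number from compound 3 to compound 4 (0.10 log units; within the scatter), because the earlier change of this kind gave a 1.5-fold higher number from compound 1 to compound 2 (0.17 log units; within the scatter), a shift within the scatter. Compound 4 is therefore estimated to give 9000 nM in this assay, with a likely range from 4500 nM to 20000 nM.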

Compound 4, half-maximal inhibitory concentration: 2400 nM
Compound 4: the middle estimate sits 3.8-fold (0.57 log units) above what was measured; measured number outside the range, below it.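

In this assay, the added methyl gives a 3.0-fold lower number from compound 3 to compound 4 (0.47 log units; beyond the scatter), so this change did not carry over with the same result from the core of compound 1 to the core of compound 3, and the two steps differ by more than the scatter allows: the same change on two cores in this assay, a 1.5-fold higher number (0.17 log units; within the scatter) from compound 1 to compound 2 and a 3.0-fold lower number (0.47 log units; beyond the scatter) from compound 3 to compound 4, 4.4-fold (0.64 log units) apart, beyond the scatter of two such steps

This does not show why the steps differ. The two pairs differ in their amine part, pyrrolidin-1-yl in one and piperidin-1-yl in the other, and also in where the methyl sits, on the chain carbon bound to the oxygen in one and two bonds along the chain from that oxygen in the other, so the compounds shown cannot separate these two differences. Within the data shown here, each core also supplies only one step, so the comparison rests on a single pair of steps and gives no general rule for the series.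

The compounds shown leave open whether ethoxy to propoxy gives a similar step when the amine part is pyrrolidin-1-yl, which would test the effect of the amine part with the position of the methyl held fixed. They also leave open whether a longer chain such as butoxy, or another amine such as morpholin-4-yl, would keep the lower number seen with compound 4.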